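Hydrazone acid series: whole-organism inhibition in the rat

The source may report more compounds than this note shows. Statements on the series, on what has been measured and on what is new or still open speak of the compounds shown alone.

Measured compounds:
compound 1, `CC1CC/C(=N\Nc2ccccc2Br)c2ncc(C(=O)O)c(=O)n21`: > 320 umol/kg
compound 2, `CC1CC/C(=N\Nc2ccc(I)cc2)c2ncc(C(=O)O)c(=O)n21`: > 1000 umol/kg
compound 3, `Cc1ccc(N/N=C2\CCC(C)n3c2ncc(C(=O)O)c3=O)cc1`: > 1000 umol/kg

Going by the values given here, in a functional assay on the whole organism for inhibition, with Rattus norvegicus as the target (a higher number here means that more compound is needed for the effect, a lower number that less compound is needed), compound 1 gives only a limit, not a number, and so it stands nowhere definite on the scale; it is the one value that sits at the limit of > 320 umol/kg in this assay, at which 1 of the 3 values shown sits. Compound 2 also gives only a limit. Compound 3 likewise gives only a limit; these two values sit at the limit of > 1000 umol/kg in this assay, at which 2 of the 3 values shown sit. The three measured steps, a step that the two limits leave unreadable from compound 1 to compound 2, a step that the two limits leave unreadable from compound 1 to compound 3 and a step that the two limits leave unreadable from compound 2 to compound 3, are therefore all of unreadable size, and none of them shows whether a change on the aromatic ring attached to the amine nitrogen moves this assay at all.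

Compound 4, `CC1CC/C(=N\Nc2ccccc2CCO)c2ncc(C(=O)O)c(=O)n21`, differs from compound 1 by 2-hydroxyethyl in place of bromo on an aromatic carbon. Among the compounds with values here, no measured step bears on this exchange in a readable way, so there is no basis for expecting a step in either direction; the most that can be said is that every measured compound of the series has failed to reach a number in this assay. Compound 4 is therefore expected to give about 500 umol/kg, with a range of 150 umol/kg to 3000 umol/kg. The step this estimate means, a step that the limit leaves unreadable from compound 1 to compound 4, is expected to stay within the scatter, with a substantial chance that only a limit is reported again.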

Compound 4, dose for 50% inhibition: > 100 umol/kg
Compound 4 ended at the assay's limit; the forecaster's own chance of this, stated with the estimate: 70%; the middle value is on the limit's open side.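

In this assay, going by these compounds alone, compound 4 gives only the limit > 100 umol/kg and compound 1 also stands at a limit, so no step between compound 1 and compound 4 can be read. Going by these compounds, whether 2-hydroxyethyl in place of bromo, or any other change on the aromatic ring, moves this assay at all remains open.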